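The source may report more compounds than this note shows. Statements on the series, on what has been measured and on what is new or still open speak of the compounds shown alone.

Of the compounds shown here, two that share one core have been measured in a physicochemical assay for permeability, using PAMPA, at pH 7.4; on this read-out lower numbers stand for lower permeability and higher numbers for higher permeability. Compound 1 `O=C(NS(=O)(=O)c1ccc(F)cc1)c1ccc(Nc2nc(NC3(c4ccc(Cl)cc4)CC3)nc(OCC(F)(F)F)n2)cc1` gives 193 nm/s. Compound 2 `O=C(NS(=O)(=O)CCNC(=O)C1CC1)c1ccc(Nc2nc(NC3(c4ccc(Cl)cc4)CC3)nc(OCC(F)(F)F)n2)cc1` gives 1 nm/s. Among the compounds with values here, the single step between them, a 190-fold lower number from compound 1 to compound 2 (2.29 log units; beyond the scatter), goes with the change of 2-((cyclopropylcarbonyl)amino)ethyl in place of 4-fluorophenyl on a sulfonyl sulfur. Compound 2 therefore stands at the lowest of the two numbers, with compound 1 far above it.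

Compound 3 `CC(C)OC(=O)NCCS(=O)(=O)NC(=O)c1ccc(Nc2nc(NC3(c4ccc(Cl)cc4)CC3)nc(OCC(F)(F)F)n2)cc1` differs from compound 2 in one place: isopropoxy in place of cyclopropyl on a carbonyl carbon, which, read one bond further out, is cyclopropylcarbonyl to isopropoxycarbonyl. Within the data shown here, no measured step tests this exact change. Among the measured compounds shown here, the only measured step, a 190-fold lower number from compound 1 to compound 2 (2.29 log units; beyond the scatter), swaps a much larger part of the molecule, so it bears on compound 3 only by showing that compound 2 already sits at the low end in this assay. The present change is small, and compound 3 is expected to move little in this assay, by about a 2.0-fold higher number from compound 2 to compound 3 (0.30 log units; within the scatter), a shift within the scatter. Compound 3 is therefore estimated at 2 nm/s, with a range from 0.5 nm/s to 8 nm/s.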

Compound 3, apparent permeability: 71 nm/s
For compound 3 the middle estimate is 36-fold (1.55 log units) below the measured one, and the stated range ends below it.
By their numbers in this assay, from the lowest: compound 2; then compound 3; then compound 1.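

In this assay the swap of isopropoxy for cyclopropyl on a carbonyl carbon gives a 71-fold higher number from compound 2 to compound 3 (1.85 log units; beyond the scatter) and so shows that exchanging one small group for another at this place can move the number a long way. The low value of compound 2 therefore does not hold for every chain on the sulfonyl sulfur: the change to 2-((isopropoxycarbonyl)amino)ethyl gives a 2.7-fold lower number from compound 1 to compound 3 (0.43 log units; beyond the scatter) and is only modest beside the change to 2-((cyclopropylcarbonyl)amino)ethyl, which gives a 190-fold lower number from compound 1 to compound 2 (2.29 log units; beyond the scatter) and stays large. Nothing in the data shown gives a reason for the large step between the two carbonyl groups.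

The compounds shown do not tell whether the loss of the ring, the entry of the oxygen or both go with the step, and an isopropyl or a cyclopropoxy group on the same carbonyl carbon would help to separate the two. Also open, as far as these compounds go, is how a free amine or a carboxylic acid at the end of the ethyl chain would read in this assay and whether a longer chain would keep the higher number.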